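Amide side chains: from methyl ester to carboxy

This account rests on a few compounds, and the source may have more. Where it says the series, first, only, none or still open, it means among the compounds named here.

Values so far in a functional assay on MCF7 cells (Homo sapiens) for antiproliferative activity, read by MTT assay, with a stated time of 48 h; on this read-out higher numbers stand for weaker inhibition and lower numbers for stronger inhibition
- compound 1 (`CCN(CC)CCNC(=O)c1ccc(C(CC)(CC)c2ccc(OCCC(O)(CC)CC)c(C)c2)n1CC`) gives 550 nM
- compound 2 (`CCn1c(C(=O)NCC#N)ccc1C(CC)(CC)c1ccc(OCCC(O)(CC)CC)c(C)c1`) gives > 50000 nM as a limit
- compound 3 (`CCC(C)C(NC(=O)c1ccc(C(CC)(CC)c2ccc(OCCC(O)(CC)CC)c(C)c2)n1CC)C(=O)OC`) gives > 50000 nM as a limit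

For compound 3 the value (> 50000 nM) is a limit and not a number. Compound 3 sits on the limit of > 50000 nM in this assay, at which 2 of the 3 values shown sit, and only compound 1 gives a number.

The next compound is compound 4 (`CCC(C)C(NC(=O)c1ccc(C(CC)(CC)c2ccc(OCCC(O)(CC)CC)c(C)c2)n1CC)C(=O)O`). The change (hydrogen in place of methyl on an oxygen next to a carbonyl group) is hydrogen in place of methyl on an oxygen next to a carbonyl group, or methoxycarbonyl to carboxy.

For the measured compounds named here, no measured step makes this same change. The nearest are an at least 90-fold higher number from compound 1 to compound 3 (1.95 log units; beyond the scatter) and an at least 90-fold higher number from compound 1 to compound 2 (1.95 log units; beyond the scatter) and both are large changes on the amide-type nitrogen. The step that the two limits leave unreadable from compound 2 to compound 3 adds nothing on size.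

Compound 4 keeps the side chain of compound 3 apart from this one hydrogen, so it is expected to stay with the inactive pair. The estimated step in this assay is an at least 1.2-fold lower number from compound 3 to compound 4 (0.09 log units; that floor lies within the scatter) and most likely stays unreadable, with any readable move going toward lower numbers. For compound 4 the estimate is 40000 nM with an expected range from 10000 nM to 60000 nM and a report as a limit is likely.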

Compound 4, half-maximal inhibitory concentration: 11300 nM
Beside the measured number, compound 4's estimate is 3.5-fold (0.55 log units) above it; the measured number falls inside the stated range.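

Methoxycarbonyl to carboxy on this side chain gives a readable value in this assay, with an at least 4.4-fold lower number from compound 3 to compound 4 (0.64 log units; beyond the scatter), and the 1-carboxy-2-methylbutyl group also stands apart from cyanomethyl on the amide-type nitrogen, with an at least 4.4-fold lower number from compound 2 to compound 4 (0.64 log units; beyond the scatter). The carboxy side chain still falls short of 2-(diethylamino)ethyl, with a 21-fold higher number from compound 1 to compound 4 (1.31 log units; beyond the scatter). The step linking compound 2 and compound 3 cannot be read, and the two steps to compound 4 are only floors, as compound 2 and compound 3 each give a limit and not a number: the limit of > 50000 nM in this assay, at which 2 of the 4 values shown sit.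

Open, from the compounds shown here alone, is whether a carboxylic acid on a shorter or longer chain, without the 2-methylbutyl part, would give a similar value. Also open, going by these compounds, is how a primary amine or a dimethylamino group at the end of the chain would compare with 2-(diethylamino)ethyl.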